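A few compounds are considered here, and "the series" means these few. Any claim that something is new, unique, unknown or untested is made for them only; others in the source may bear on it.

Measured in a functional assay (strain AB) with Danio rerio as the target, read by microscopy, with a stated time of 1 h; a lower number here means that less compound is needed, a higher number that more compound is needed for the effect:
- Compound 1 `CCN1CCc2c(sc(NC(=O)Nc3ccc(Cl)cc3)c2C(N)=O)C1` gives 3120 nM
- Compound 2 `CN1CCc2c(sc(NC(=O)Nc3ccc(Cl)cc3)c2C(N)=O)C1` gives 4700 nM
- Compound 3 `NC(=O)c1c(NC(=O)Nc2ccc(Cl)cc2)sc2c1CCN(C1CCOCC1)C2` gives 2830 nM

Compound 3 stands within the scatter of both others (a 1.1-fold lower number from compound 1 to compound 3 (0.04 log units; within the scatter) and a 1.7-fold lower number from compound 2 to compound 3 (0.22 log units; within the scatter)). Compound 4 `CC(C)(C)OC(=O)CCN1CCc2c(sc(NC(=O)Nc3ccc(Cl)cc3)c2C(N)=O)C1` carries 2-(tert-butoxycarbonyl)ethyl in place of oxan-4-yl on an amine nitrogen in a ring. The third measured step (a 1.5-fold higher number from compound 1 to compound 2 (0.18 log units; within the scatter)) also stayed small, so all three changes to this substituent remained within the scatter. None of them introduced a group like 2-(tert-butoxycarbonyl)ethyl, so the evidence is only indirect and a wide range is warranted. No shift beyond the scatter is expected in this assay, and the expected change is (a 1.1-fold higher number from compound 3 to compound 4 (0.03 log units; within the scatter)). The estimate for compound 4 is (3000 nM), with an expected range from (1300 nM) to (7000 nM).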

Compound 4, half-maximal effective concentration: 1100 nM
Compound 4: middle estimate off by 2.7-fold (0.44 log units), on the high side; measured number below the stated range.
By their numbers in this assay, from the lowest: compound 4; then compounds 3, 1 and 2 (each within the scatter of the next).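

Among the compounds shown here, on the amine nitrogen in a ring, 2-(tert-butoxycarbonyl)ethyl is the first group to move the number in this assay beyond the scatter (a 2.6-fold lower number from compound 3 to compound 4 (0.41 log units; beyond the scatter); a 4.3-fold lower number from compound 2 to compound 4 (0.63 log units; beyond the scatter); a 2.8-fold lower number from compound 1 to compound 4 (0.45 log units; beyond the scatter)). Methyl, ethyl and oxan-4-yl had stayed within the scatter of one another, so this position does respond to its substituent, with less compound needed for the effect. No measurement at hand explains the shift.

The compounds shown leave open whether the tert-butyl ester or the chain itself matters: a free carboxylic acid, or a plain butyl chain on the same nitrogen, would separate the two.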